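Swapping ethoxy for methylsulfanyl on a hydroxy-bearing core

The source may report more compounds than this note shows. Statements on the series, on what has been measured and on what is new or still open speak of the compounds shown alone.

Compound 1 `CCOc1ccc(C2C(C3CC3)C(=O)N2c2cc(OC)c(OC)c(OC)c2)cc1` and compound 2 `COc1cc(N2C(=O)C(C3CC3)C2c2ccc(SC)cc2)cc(OC)c1OC` share one core, while compound 3 `CCOc1ccc(C2C(O)C(=O)N2c2cc(OC)c(OC)c(OC)c2)cc1` and compound 4 `COc1cc(N2C(=O)C(O)C2c2ccc(SC)cc2)cc(OC)c1OC` share another; compound 4 has not yet been measured. In a functional assay on HL-60 cells (Homo sapiens) for inhibition, read by resazurin assay, with a stated time of 72 h (a higher number here means a weaker inhibitor, a lower number a stronger inhibitor), compound 1 gives 201 nM, compound 2 gives 279 nM, and compound 3 gives 11 nM.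

Compound 2 differs from compound 1 by methylsulfanyl in place of ethoxy on an aromatic carbon, and this change gave a 1.4-fold higher number from compound 1 to compound 2 (0.14 log units; within the scatter). The two cores differ as described by hydroxy in place of cyclopropyl on a saturated ring carbon, and that change gave an 18-fold lower number from compound 1 to compound 3 (1.26 log units; beyond the scatter), which leaves compound 3 as the lowest number of the three measured compounds.

Compound 4 differs from compound 3 by methylsulfanyl in place of ethoxy on an aromatic carbon, the same change that turns compound 1 into compound 2, made at the same place on the same kind of ring. For the measured compounds named here, the only measured example of this change stayed within the scatter of repeated measurements. The expectation for compound 4 rests on that single example, which gave a 1.4-fold higher number from compound 1 to compound 2 (0.14 log units; within the scatter). For compound 4 the expected step is therefore a 1.4-fold higher number from compound 3 to compound 4 (0.13 log units; within the scatter). Compound 4 is accordingly estimated at 15 nM, most likely falling between 7 nM and 35 nM.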

Compound 4, half-maximal inhibitory concentration: 15 nM
The estimate for compound 4 equals the measured number at the digits printed; measured number inside the range.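

In this assay, replacing the 4-ethoxyphenyl group with 4-(methylsulfanyl)phenyl on the hydroxy-bearing core gave a 1.4-fold higher number from compound 3 to compound 4 (0.13 log units; within the scatter), and this step matches the one seen on the cyclopropyl-bearing core: the same change on two cores in this assay, a 1.4-fold higher number (0.14 log units; within the scatter) from compound 1 to compound 2 and a 1.4-fold higher number (0.13 log units; within the scatter) from compound 3 to compound 4, 1.0-fold (0.01 log units) apart, within the scatter of two such steps

The change of cyclopropyl to hydroxy, made with methylsulfanyl in place of ethoxy, gave a 19-fold lower number from compound 2 to compound 4 (1.27 log units; beyond the scatter), and this large step also carried over: the same change on two cores in this assay, an 18-fold lower number (1.26 log units; beyond the scatter) from compound 1 to compound 3 and a 19-fold lower number (1.27 log units; beyond the scatter) from compound 2 to compound 4, 1.0-fold (0.01 log units) apart, within the scatter of two such steps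

Among these four compounds, each change therefore had about the same size whichever form of the other group was present, but this comes from a single pair of cores in one cell assay, and it neither explains the steps nor shows that they would hold on other cores.

The compounds shown leave open whether an amine or a carboxylic acid on the saturated ring carbon, where hydroxy sits, would give a number as low as hydroxy does. They also leave open whether a longer chain, such as butoxy, would fit the same pattern in place of ethoxy on the aromatic ring.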